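From a chlorothiophene sulfonamide to an ethylphenyl one

The source may report more compounds than this note shows. Statements on the series, on what has been measured and on what is new or still open speak of the compounds shown alone.

Three sulfonamides built on one shared core have been examined in an assay on cells for inhibition of HSP60/HSP10 (Homo sapiens), with a stated time of 60 min; on this read-out higher numbers stand for weaker inhibition and lower numbers for stronger inhibition. Compound 1 `O=S(=O)(Nc1ccc(-c2nc3ccccc3o2)cc1)c1ccccc1O` gives > 100000 nM, which is a limit of the assay and not a number. Compound 2 `COc1ccc(Cl)cc1S(=O)(=O)Nc1ccc(-c2nc3ccccc3o2)cc1` likewise gives > 100000 nM, again a limit. Within the data shown here, compound 3 `O=S(=O)(Nc1ccc(-c2nc3ccccc3o2)cc1)c1ccc(Cl)s1` is the only compound with a true number, giving 31000 nM in this assay. The steps of an at least 3.2-fold lower number from compound 1 to compound 3 (0.50 log units; beyond the scatter) and an at least 3.2-fold lower number from compound 2 to compound 3 (0.50 log units; beyond the scatter) are both at least modest, and they are the only readable ones, since the limit of > 100000 nM in this assay, at which 2 of the 3 values shown sit, leaves the step from compound 1 to compound 2 unreadable.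

Compound 4 `CCc1ccc(S(=O)(=O)Nc2ccc(-c3nc4ccccc4o3)cc2)cc1` is not yet measured. It differs from compound 3 by 4-ethylphenyl in place of 5-chlorothiophen-2-yl on a sulfonyl sulfur. Among the measured compounds shown here, both readable steps moved toward the 5-chlorothiophen-2-yl group and lowered the number; compound 4 moves away from that group back to a six-membered ring of carbon only, so a rise toward the limit is expected, though the 4-ethylphenyl group has no counterpart among the measured compounds. Compound 4 is therefore expected to give 60000 nM in this assay, within 20000 nM to 200000 nM, a step of a 1.9-fold higher number from compound 3 to compound 4 (0.29 log units; within the scatter) that may end at the limit.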

Compound 4, half-maximal inhibitory concentration: > 100000 nM
Compound 4 ended at the assay's limit; the forecaster's own chance of this, stated with the estimate: 40%; middle value at least 1.6-fold (0.22 log units) away from the limit.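

Swapping 5-chlorothiophen-2-yl for 4-ethylphenyl on the sulfonyl sulfur gives an at least 3.2-fold higher number from compound 3 to compound 4 (0.50 log units; beyond the scatter) in this assay, so the loss seen with compound 1 and compound 2 also appears with a six-membered ring of carbon only that has no hydroxy, methoxy or chloro group. Among the four compounds, all of which vary only at this position, compound 3 alone gives a true number, and none goes against this. The steps from compound 1 and from compound 2 to compound 4 cannot be read, because both ends of each are limits and not numbers: the limit of > 100000 nM in this assay, at which 3 of the 4 values shown sit.

Whether the chlorine or the five-membered ring accounts for the difference remains open. A plain thiophen-2-yl group or a 4-chlorophenyl group on the sulfonyl sulfur would separate the two.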